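Replacing One Group on Compound 2

The source may report more compounds than this note shows. Statements on the series, on what has been measured and on what is new or still open speak of the compounds shown alone.

Compound 1 `CC(O)(CSc1cccc(S(F)(F)(F)(F)F)c1)C(=O)Nc1ccc(S(F)(F)(F)(F)F)cc1`: 17700 nM
Compound 2 `CC(O)(COc1ccc(S(F)(F)(F)(F)F)cc1)C(=O)Nc1cccc(S(F)(F)(F)(F)F)c1`: 10200 nM

In a functional assay on CWR22R cells (Homo sapiens) for antiproliferative activity, read by propidium iodide staining, with a stated time of 96 h (a lower number here means a stronger inhibitor, a higher number a weaker inhibitor), compound 2 gives 10200 nM and compound 1 gives 17700 nM, so the two stand level within the scatter. Compound 3 `CC(O)(COc1ccc(C(F)(F)F)cc1)C(=O)Nc1cccc(S(F)(F)(F)(F)F)c1` departs from compound 2 at one place, on an aromatic carbon, para to a large group: a group of 4 heavy atoms (1 carbon, 3 fluorine; no ring) in place of a group of 6 heavy atoms (5 fluorine, 1 sulfur; no ring), on an aromatic carbon. Within the data shown here, no measured pair shows this change, so its size cannot be read from the data. No step beyond the scatter is expected in this assay, and the estimate starts from compound 2 at 10200 nM. The expected change is a 1.2-fold higher number from compound 2 to compound 3 (0.07 log units; within the scatter). Compound 3 is estimated at 12000 nM, with an expected range of 5000 nM to 30000 nM.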

Compound 3, half-maximal inhibitory concentration: 3600 nM
Compound 3: middle estimate off by 3.3-fold (0.52 log units), on the high side; the whole stated range lies above it.
By their numbers in this assay, from the lowest: compound 3; then compounds 2 and 1 (each within the scatter of the next).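

In this assay, the aromatic carbon para to a large group responds to this exchange: trifluoromethyl entering in place of the group of 5 fluorine and 1 sulfur gives a 2.8-fold lower number from compound 2 to compound 3 (0.45 log units; beyond the scatter) in the number. Among these compounds, compounds 1 and 2 differ in more than one place, so this is the first single change that can be read on its own. Nothing given here bears on the reason for this step.

Going by these compounds, whether a chlorine atom, a nitrile or a methyl group on the same carbon would go further remains open. A single pair also leaves open whether this exchange would give a similar step elsewhere on the shared core.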